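Furan-2-yl to Thiophen-3-yl on a Shared Core

The source may hold more compounds than are shown below. What is called first, only, known or untested is meant among the compounds shown, and "the series" means these compounds.

Of the compounds shown here, three built on one shared core have been tested in an assay on membranes from HeLa cells for displacement of a labelled ligand from adenosine receptor A3 (Homo sapiens), read by scintillation counting, with a stated time of 180 min, tested at 1 uM; a higher number here means more inhibition at the concentration tested (going by the name of the read-out), a lower number less inhibition. Compound 1 `CC1=C(C(=O)C2CC2)C(c2ccco2)NC(=O)N1` gives 7% there. Compound 2 `CCCC(=O)C1=C(C)NC(=O)NC1c1ccco1` gives 1% in this assay. Compound 3 `CCN(CC)C(=O)C1=C(C)NC(=O)NC1c1ccco1` gives 19% in this assay. The steps among them all change the group on the carbonyl carbon: a number 6 percentage points lower from compound 1 to compound 2 (within the scatter), a number 12 percentage points higher from compound 1 to compound 3 (beyond the scatter) and a number 18 percentage points higher from compound 2 to compound 3 (beyond the scatter). On these numbers compound 3 stands highest, beyond the scatter from both others.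

Compound 4 `CCN(CC)C(=O)C1=C(C)NC(=O)NC1c1ccsc1` keeps the diethylamino group of compound 3 and differs only in the five-membered ring on the saturated ring carbon: thiophen-3-yl in place of furan-2-yl on a saturated ring carbon. Going by the values given here, none of the measured steps touches that position, so they give no direct guide to the size or direction of this change. With nothing in the data pointing either way, the expected step in this assay is none beyond the scatter: no change at the digits printed from compound 3 to compound 4 (within the scatter). Compound 4 is therefore estimated at 19%, with a range from 5% to 35%.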

Compound 4, a percentage reported as inhibition, at one concentration (the size of the read-out at that concentration, not a potency): 35%
Compound 4: middle estimate off by 16 percentage points, on the low side; the range from low to high includes it.
By their numbers in this assay, from the lowest: compounds 2 and 1 (each within the scatter of the next); then compound 3; then compound 4.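

Holding the diethylamino group fixed, thiophen-3-yl in place of furan-2-yl on the saturated ring carbon gives a number 16 percentage points higher from compound 3 to compound 4 (beyond the scatter) in this assay, so this position, and not only the group on the carbonyl carbon, can move the read-out. The two rings match in heavy atoms and hydrogen-bond acceptors but differ in their hetero atom, oxygen against sulfur, and in the ring position named in each group, so this single step cannot separate those two changes. Nothing at hand gives a cause for the rise.

Thiophen-2-yl, furan-3-yl or phenyl on the same carbon would help to pull these changes apart. Also open, as far as these compounds go, is whether thiophen-3-yl has a similar effect with cyclopropyl or propyl on the carbonyl carbon, as in compound 1 and compound 2.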